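This account rests on a few compounds, and the source may have more. Where it says the series, first, only, none or still open, it means among the compounds named here.

Among the measured compounds shown here, compound 1 `COc1ccccc1/C=C/C(=O)c1ccc(OCC(=O)N[C@H]2CCOC2=O)cc1` is the one member of this small set for which a functional assay on PC-3 cells (Homo sapiens) for antiproliferative activity, read by MTT assay, with a stated time of 72 h (a lower number here means a stronger inhibitor, a higher number a weaker inhibitor), returns a number: in this assay compound 1 gives 7240 nM. The two other compounds stop at a limit of the assay. Compound 2 `Cc1ccc(C(C)C)c(OCCSC(=S)N[C@H]2CCOC2=O)c1` gives > 64000 nM in this assay, a limit rather than a measured number. Compound 3 `O=C(CNc1ccc(Cl)cc1)N[C@H]1CCOC1=O` likewise gives > 64000 nM in this assay, again a limit. So the limit of > 64000 nM in this assay, at which 2 of the 3 values shown sit, marks where two of the three values stand, and compound 1 alone lies inside the measurable range, which makes it the only reference point for the step that follows.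

Compound 4 `O=C(COc1ccc(C(=O)/C=C/c2cccc([N+](=O)[O-])c2)cc1)N[C@H]1CCOC1=O` keeps the core of compound 1 and changes one group: 3-nitrophenyl in place of 2-methoxyphenyl on a double-bonded chain carbon bound to a double-bonded chain carbon. For the measured compounds named here, no pair of measured compounds here differs in a single place, so no measured step shows how large such a swap tends to be. With that in mind, the step from compound 1 to compound 4 in this assay is expected to be small, of a size that may not exceed the scatter of repeated measurements, and if anything toward slightly stronger inhibition. Compound 4 is therefore estimated at 5000 nM in this assay, with a range from 1500 nM to 20000 nM. That estimate corresponds to an expected step of a 1.4-fold lower number from compound 1 to compound 4 (0.16 log units; within the scatter).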

Compound 4, half-maximal inhibitory concentration: 56300 nM
The estimate for compound 4 lay 11-fold (1.05 log units) below the measured number; measured number outside the range, above it.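

In this assay, putting 3-nitrophenyl in place of 2-methoxyphenyl on a double-bonded chain carbon bound to a double-bonded chain carbon gives a 7.8-fold higher number from compound 1 to compound 4 (0.89 log units; beyond the scatter). Among the compounds shown here, this is the first comparison in the set between compounds that differ in one place, and it shows that the group at this place is not a passive part of the molecule: with the rest of the core of compound 1 unchanged, this swap alone moves the result toward weaker inhibition by more than the scatter. Compound 4 still returns a measured number, but the change carries the series toward the upper edge of what the assay can read: the limit of > 64000 nM in this assay, at which 2 of the 4 values shown sit.

A single pair cannot separate what is lost with 2-methoxyphenyl from what is brought in by 3-nitrophenyl, so it gives no general rule for this place. As far as these compounds go, whether a plain phenyl, or a phenyl carrying an amine or a carboxylic acid, would stay close to compound 1 or move toward compound 4 remains open.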